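This account rests on a few compounds, and the source may have more. Where it says the series, first, only, none or still open, it means among the compounds named here.

Compound 1 `O=C1COc2ccc(-c3cnc(Cl)c(NS(=O)(=O)c4ccc(F)cc4)c3)cc2N1c1ccc(F)cc1` is the starting point of this account. Going by the values given here, in a functional assay on MCF7 cells (Homo sapiens) for antiproliferative activity, read by MTT assay, with a stated time of 72 h (a lower number here means a stronger inhibitor, a higher number a weaker inhibitor), compound 1 gives 32600 nM, the only number among the values shown. Compound 2 `O=C1COc2ccc(-c3ccc(O)cc3)cc2N1` gives in this assay only a limit, > 40000 nM, which is the limit of > 40000 nM in this assay, at which 1 of the 2 values shown sits. Compound 1 therefore stands alone as a measured number. The unmeasured compound 3 `O=C1COc2ccc(-c3cnc(Cl)c(NS(=O)(=O)c4ccc(F)cc4)c3)cc2N1C1CC1` differs from compound 1 in one place: cyclopropyl in place of 4-fluorophenyl on an amide-type nitrogen in a ring. Among the compounds with values here, no measured pair in the set shares this change, so its effect in this assay is unknown; since compound 1 sits at 32600 nM, a step of no more than the usual scatter is expected in either direction, with the weaker side somewhat more likely. The estimated step of a 1.2-fold higher number from compound 1 to compound 3 (0.09 log units; within the scatter) is accordingly small. Compound 3 is expected to give about 40000 nM in this assay, with a range from 15000 nM to 100000 nM.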

Compound 3, half-maximal inhibitory concentration: 16700 nM
Beside the measured number, compound 3's estimate is 2.4-fold (0.38 log units) above it; low and high end bracket the measured number.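

Going by these compounds alone, on the amide-type nitrogen in a ring, cyclopropyl in place of 4-fluorophenyl gives the first measured step in this assay (a 2.0-fold lower number from compound 1 to compound 3 (0.29 log units; within the scatter)). This position therefore takes a group of 3 heavy atoms with a three-membered non-aromatic ring in place of one of 7 heavy atoms with a six-membered aromatic ring, and the change stays within the usual scatter, so the aromatic ring at this place is not shown to matter in this assay. Nothing shown bears on why the step has this size.

As far as these compounds go, whether a methyl group, a longer chain or a chain ending in an amine on this nitrogen would move the number beyond the scatter remains open. Also open, from the compounds shown here alone, is how far the shared core of compound 1 and compound 3 would respond to a carboxylic acid elsewhere on it.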